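Working notes: the step from compound 2 to compound 3

The compounds below may be only part of what the source reports. "The series", "measured", "known", "first", "only" and "open" are said of these compounds alone.

In an ADME assay on MDBK cells (Bos taurus) for cytotoxicity, read by MTT assay, with a stated time of 96 h (a lower number here means that less compound is tolerated, a higher number that more compound is tolerated), compound 1 `COc1cccc(NC(=S)Nc2cccc(C(F)(F)F)c2)c1` gives 52000 nM and compound 2 `Fc1ccc(NC(=S)Nc2cccc(C(F)(F)F)c2)cc1` gives 41000 nM, so the two stand within the scatter of each other. Compound 3 `FC(F)(F)c1cccc(NC(=S)Nc2cccc(Br)c2)c1` carries 3-bromophenyl in place of 4-fluorophenyl on an amide-type nitrogen. Within the data shown here, no measured step covers this change, so the expectation rests on these two values alone: a small step in this assay towards a lower number, not clearly beyond the scatter. The expected move is a 1.4-fold lower number from compound 2 to compound 3 (0.14 log units; within the scatter). Compound 3 is estimated at 30000 nM, with an expected range of 12000 nM to 70000 nM.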

Compound 3, half-maximal cytotoxic concentration: 10000 nM
The estimate for compound 3 lay 3.0-fold (0.48 log units) above the measured number; measured number outside the range, below it.
By their numbers in this assay, from the lowest: compound 3; then compounds 2 and 1 (each within the scatter of the next).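

In this assay the group on the amide-type nitrogen whose other neighbour is the thiocarbonyl carbon proves able to move the number: 3-bromophenyl in place of 4-fluorophenyl gives a 4.1-fold lower number from compound 2 to compound 3 (0.61 log units; beyond the scatter) and bromo in place of methoxy on an aromatic carbon gives a 5.2-fold lower number from compound 1 to compound 3 (0.72 log units; beyond the scatter). Compound 1 and compound 2, within the scatter of each other, gave no sign of this. Nothing available accounts for these steps. Still open, as far as these compounds go, is whether the bromo itself or its place on the ring carries the step. Also open, from the compounds shown here alone, is how an amine or a carboxylic acid on this ring would read.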